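This account rests on a few compounds, and the source may have more. Where it says the series, first, only, none or still open, it means among the compounds named here.

Measured compounds:
- compound 1, `CSc1cc(C)nc(NC(=S)NC(=O)c2c(-c3ccc(Cl)cc3Cl)noc2C)n1`, in a functional assay on the whole organism for inhibition, with Brassica napus as the target, with a stated time of 72 h, tested at 10 mg/L (on this read-out higher numbers stand for more inhibition of growth at the one concentration tested and lower numbers for less inhibition of growth), compound 1 gives 42.4%
- compound 2, `COc1cc(OC)n2s/c(=N\C(=O)c3c(-c4ccc(Cl)cc4Cl)noc3C)nc2n1`, in this assay compound 2 gives 49.3%

Among the measured compounds shown here, compound 2 stands with the higher of the two numbers, but its only neighbour, compound 1, sits a distance below it that lies within the usual scatter, so the two compounds cannot be put in order and count as alike on this read-out. For the measured compounds named here, the two share the same acyl part and differ in the heterocycle carrying it, and no step between them has been worked out, so the data give no measured step to lean on.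

Compound 3, `COc1cc(SC)nc2n/c(=N/C(=O)c3c(-c4ccc(Cl)cc4Cl)noc3C)sn12`, has not yet been tested. It differs from compound 2 by one change: methylsulfanyl in place of methoxy on an aromatic carbon. Going by the values given here, since no measured step exists that would show how this kind of exchange moves the read-out, the step is expected to stay within the scatter, in no particular direction. Compound 3 is therefore estimated at 48%, within a range of 35% to 62%, which means an expected step of a number 1.3 percentage points lower from compound 2 to compound 3 (within the scatter).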

Compound 3, percent growth inhibition at one concentration: 27.4%
Beside the measured number, compound 3's estimate is 20.6 percentage points above it; measured number outside the range, below it.
By their numbers in this assay, from the lowest: compound 3; then compounds 1 and 2 (each within the scatter of the next).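

In this assay, among the compounds shown here, the exchange of methoxy for methylsulfanyl on this aromatic carbon gives a number 21.9 percentage points lower from compound 2 to compound 3 (beyond the scatter) and so shows that this position is not indifferent to the group it carries, which the earlier compounds could not show, as they offered no step in one place. The change itself is small by what is counted: both groups have 2 heavy atoms, no ring and 1 hydrogen-bond acceptor, and oxygen gives way to sulfur, yet the step lies beyond the usual scatter. Nothing measured on these compounds accounts for the drop in growth inhibition, so the step stands as an observation without an explanation.

A single pair leaves open whether the same exchange would give a similar step at the other methoxy group, which compound 3 keeps, or on another core. It also leaves open how this position would respond to a group of another kind, such as an amine, a chlorine atom or a longer chain like butoxy, and so whether methoxy is a favourable group here or methylsulfanyl an unfavourable one.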